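The compounds below may be only part of what the source reports. "The series", "measured", "known", "first", "only" and "open" are said of these compounds alone.

Compound 2, `Cn1ncc(Cl)c1-c1cc(C(=O)N[C@@H]2CN[C@H](CCN3CCC(O)CC3)C[C@H]2c2ccc(Cl)c(Cl)c2)oc1Cl`, is the weaker of the two measured compounds in an assay for inhibition of RAC-alpha serine/threonine-protein kinase (Homo sapiens), read by HTRF, with a stated time of 1 h (on this read-out lower numbers stand for stronger inhibition and higher numbers for weaker inhibition), where compound 2 gives 5.99 nM. Within the data shown here, its only measured neighbour is compound 1, `CNC(=O)C[C@@H]1C[C@@H](c2ccc(Cl)c(Cl)c2)[C@H](NC(=O)c2cc(-c3c(Cl)cnn3C)c(Cl)o2)CN1`, which in this assay gives 2.64 nM; the single measured step is a 2.3-fold higher number from compound 1 to compound 2 (0.36 log units; beyond the scatter). Compound 3, `COCC[C@@H]1C[C@@H](c2ccc(Cl)c(Cl)c2)[C@H](NC(=O)c2cc(-c3c(Cl)cnn3C)c(Cl)o2)CN1`, has not been measured. Its difference from compound 2 is methoxy in place of 4-hydroxypiperidin-1-yl on a saturated chain carbon, two bonds along the chain from a saturated ring carbon, that is, a methoxy in place of the 4-hydroxypiperidin-1-yl on the same chain. Among the measured compounds shown here, the one measured step exchanges a different group at a different place on that chain, so it bears on the new change only loosely, and it shows that changes on this chain have so far moved the number modestly. A step of similar small size, in either direction, is therefore expected, as a 1.1-fold lower number from compound 2 to compound 3 (0.04 log units; within the scatter). Compound 3 is estimated at 5.5 nM, within a range of 2 nM to 16 nM.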

Compound 3, half-maximal inhibitory concentration: 7.01 nM
Compound 3: middle estimate off by 1.3-fold (0.11 log units), on the low side; measured number inside the range.
By their numbers in this assay, from the lowest: compound 1; then compounds 2 and 3 (each within the scatter of the next).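

In this assay, methoxy in place of 4-hydroxypiperidin-1-yl on this chain gives a 1.2-fold higher number from compound 2 to compound 3 (0.07 log units; within the scatter), so going from the group of 7 heavy atoms with its six-membered ring and hydrogen-bond donor to one of 2 heavy atoms with neither leaves no difference that can be read. Compound 1 now stands apart from both: alongside a 2.3-fold higher number from compound 1 to compound 2 (0.36 log units; beyond the scatter) there is a 2.7-fold higher number from compound 1 to compound 3 (0.42 log units; beyond the scatter), so the two very different replacements of methylcarbamoyl give steps of modest size in the same direction. The data shown offer nothing that accounts for these numbers.

On these data alone, whether a primary amine or a carboxylic acid on this chain would stay with compounds 2 and 3 or come closer to compound 1 remains open. So does the effect of a longer chain ending in methoxy.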